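One Tail Change Starting From a Limit

The compounds below may be only part of what the source reports. "The series", "measured", "known", "first", "only" and "open" are said of these compounds alone.

Compound 1, `N#CNC(=N)NCCCCCn1nc(-c2ccccc2)ccc1=O`: > 100 mg/kg
Compound 2, `CC/N=C(/NC#N)NCCCn1nc(-c2ccccc2)ccc1=O`: 78.3 mg/kg
Compound 3, `CC/N=C(/NC#N)NCCCCCCn1nc(-c2ccccc2)ccc1=O`: > 100 mg/kg

In a functional assay on the whole organism (stomach) with Rattus norvegicus as the target (a higher number here means that more compound is needed for the effect, a lower number that less compound is needed), compound 1 gives > 100 mg/kg, which is a limit of the assay rather than a number. Compound 3 also sits at a limit in this assay, with > 100 mg/kg. Compound 2 gives a number, 78.3 mg/kg. Two of the three results are therefore only a boundary: the limit of > 100 mg/kg in this assay, at which 2 of the 3 values shown sit. The step of an at least 1.2-fold lower number from compound 1 to compound 2 (0.10 log units; that floor lies within the scatter) is only a floor that lies within the scatter, and the step that the two limits leave unreadable from compound 1 to compound 3 cannot be read at all. Going by the values given here, compound 1 thus stands at a limit, with no measured step from it that shows a real change.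

Compound 4, `CC(C)C/N=C(\S)NCCCCn1nc(-c2ccccc2)ccc1=O`, differs from compound 1 in one place: a group of 8 heavy atoms (5 carbon, 2 nitrogen, 1 sulfur; no ring) in place of a group of 7 heavy atoms (3 carbon, 4 nitrogen; no ring), on a saturated chain carbon, four bonds along the chain from an aromatic nitrogen. Among the compounds with values here, neither measured step covers this change, and the one readable step from compound 1 stays within the scatter. The expected step of a number no higher from compound 1 to compound 4 (the limit leaves the size open) is therefore an estimate of no change beyond the scatter. Compound 4 is expected to give 100 mg/kg, estimated between 30 mg/kg and 300 mg/kg.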

Compound 4, dose for half-maximal effect: > 100 mg/kg
Compound 4 was reported as a limit (the forecaster's own chance of this, stated with the estimate: 55%); the middle value lies on the limit itself.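

In this assay compound 4 gives > 100 mg/kg as a limit, not a number. Going by these compounds alone, compound 1 also stands at a limit, so no step between compound 1 and compound 4 can be read: the limit of > 100 mg/kg in this assay, at which 3 of the 4 values shown sit. The compounds shown leave open how much of compound 1 or compound 4 the effect actually takes, and whether this change of group alters that amount at all.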